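Removing a methyl from a pyridine ether: a small, uncertain step

The source may hold more compounds than are shown below. What is called first, only, known or untested is meant among the compounds shown, and "the series" means these compounds.

Compound 1 `COc1ccc(-n2cnc3cnc(-c4ccc(F)cc4C)cc32)cc1` is the starting point; in a functional assay on HL-60 cells (Homo sapiens) for activation, read by flow cytometry, with a stated time of 4 days (a lower number here means that less compound is needed, a higher number that more compound is needed for the effect), compound 1 gives 6 nM. Compound 2 `COc1ccc(-n2cnc3cnc(-c4ccc(F)cc4C)cc32)cn1` carries 6-methoxypyridin-3-yl in place of 4-methoxyphenyl on an aromatic nitrogen, and in this assay compound 2 gives 70 nM, the higher of the two numbers shown, as the step of a 12-fold higher number from compound 1 to compound 2 (1.07 log units; beyond the scatter) makes clear.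

Compound 3 `Cc1cc(F)ccc1-c1cc2c(cn1)ncn2-c1ccc(O)nc1` differs from compound 2 in one place: hydrogen in place of methyl on an oxygen on an aromatic ring, so that methoxy becomes hydroxy and 6-methoxypyridin-3-yl becomes 6-hydroxypyridin-3-yl. Among the compounds with values here, no measured step touches that oxygen; the only step known swaps the ring it sits on, so it offers no direct guide. An estimate must therefore lean on compound 2 itself, with wide bounds, and a modest rise is expected, a 2.1-fold higher number from compound 2 to compound 3 (0.33 log units; beyond the scatter). Compound 3 is expected to give about 150 nM, between 30 nM and 800 nM.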

Compound 3, half-maximal effective concentration: > 10000 nM
Compound 3 ended at the assay's limit; the forecaster's own chance of this, stated with the estimate: 5%; middle value at least 66-fold (1.82 log units) from the limit.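

In this assay compound 3 gives > 10000 nM as a limit of the assay and not as a number: the limit of > 10000 nM in this assay, at which 1 of the 3 values shown sits.

Replacing the methyl on this oxygen with hydrogen, so that methoxy becomes hydroxy, brings an at least 140-fold higher number from compound 2 to compound 3 (2.15 log units; beyond the scatter) and shows that a change of one carbon at this oxygen can matter greatly, something the ring swap alone could not reveal. Measured against the starting point, the whole change is an at least 1600-fold higher number from compound 1 to compound 3 (3.22 log units; beyond the scatter) so the rise seen with compound 2 was only part of what this end of the molecule can cost.

Still open, going by these compounds, is whether this oxygen needs a methyl in particular or simply something other than hydrogen, which an ethoxy group, a longer chain on the oxygen or an amine in its place would help to settle. A 4-hydroxyphenyl group would show whether hydroxy has the same effect without the pyridine ring.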